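Extending the amide side chain of compound 2

This account rests on a few compounds, and the source may have more. Where it says the series, first, only, none or still open, it means among the compounds named here.

Two compounds from this series carry a measurement in a functional assay on NCI-H1975 cells (Homo sapiens) for antiproliferative activity, read by MTT assay, with a stated time of 72 h; a higher number here means a weaker inhibitor, a lower number a stronger inhibitor. Compound 1 `CC/C=C\C(=O)Nc1cc(Nc2nc(C)cc(-c3cn(C)c4ccccc34)n2)c(OC)cc1N(C)CCN(C)C` gives 1990 nM. Compound 2 `C=CC(=O)Nc1cc(Nc2nc(C)cc(-c3cn(C)c4ccc(F)cc34)n2)c(OC)cc1N(C)CCN(C)C` differs from compound 1 in several places. In this assay compound 2 gives 3830 nM. Compound 2 therefore has the highest of the two numbers, but its nearest neighbour, compound 1, lies within the usual scatter of this assay, so the two values cannot be told apart.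

Compound 3 `CC/C=C\C(=O)Nc1cc(Nc2nc(C)cc(-c3cn(C)c4ccc(F)cc34)n2)c(OC)cc1N(C)CCN(C)C` has not yet been measured. It differs from compound 2 in one place: but-1-en-1-yl in place of vinyl on a carbonyl carbon whose other neighbour is an amide-type nitrogen. Going by the values given here, the same but-1-en-1-yl chain is already present in compound 1, yet compound 1 and compound 2 are not a single-change pair, so no measured step speaks directly to this exchange.

On this basis the step from compound 2 to compound 3 is expected to be small, a 1.4-fold lower number from compound 2 to compound 3 (0.14 log units; within the scatter), with no clear direction beyond the scatter. Compound 3 is estimated at 2800 nM, within a range from 900 nM to 9000 nM.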

Compound 3, half-maximal inhibitory concentration: 10400 nM
Compound 3: the middle estimate sits 3.7-fold (0.57 log units) below what was measured; the measured number lies above the stated range.
By their numbers in this assay, from the lowest: compounds 1 and 2 (each within the scatter of the next); then compound 3.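

In this assay, but-1-en-1-yl in place of vinyl on a carbonyl carbon whose other neighbour is an amide-type nitrogen gives a 2.7-fold higher number from compound 2 to compound 3 (0.43 log units; beyond the scatter) and so, with the fluoro group present, this exchange on the carbonyl carbon is a measurable loss of activity and not a neutral change. Compound 1 and compound 3 form a second single-change pair, which shows that with the but-1-en-1-yl chain held fixed, fluoro in place of hydrogen on an aromatic carbon gives a 5.2-fold higher number from compound 1 to compound 3 (0.72 log units; beyond the scatter) and is also a loss beyond the scatter. Nothing shown here explains either step, and the reason for these losses remains unknown.

As far as these compounds go, it remains open whether the longer chain would cost the same without the fluoro group, and whether the fluoro group would cost the same with vinyl on the carbonyl carbon, since each step has been read in only one setting. Also open, from the compounds shown here alone, is how a saturated butyl chain, a shorter propenyl chain or a butenyl chain ending in a dimethylamino group would compare with vinyl on the carbonyl carbon, and how chloro or methoxy would compare with fluoro on the aromatic carbon.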